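The source may report more compounds than this note shows. Statements on the series, on what has been measured and on what is new or still open speak of the compounds shown alone.

Of the compounds shown here, three have numbers so far in a functional assay on HUVEC cells (Homo sapiens) for inhibition, using NADPH, with a stated time of 2 h; a lower number here means a stronger inhibitor, a higher number a weaker inhibitor. Compound 1 `Cc1c(COc2cccc(OCC3CCOCC3)c2)[nH]c2ccc(C(=O)O)cc2c1=O` gives 400 nM, the highest of the three numbers, which makes it the weakest inhibitor of the set, and its gaps to both of the others lie beyond the usual scatter. Compound 3 `Cc1c(COc2cc(OCC3CCOCC3)ccn2)[nH]c2ccccc2c1=O` gives 49 nM, while compound 2 `CCCCCCCCCc1[nH]c2ccccc2c(=O)c1C`, whose structure looks quite different from the other two, gives 5.6 nM.

The next compound to be tested, compound 4 `Cc1c(COc2cccc(OCC3CCOCC3)c2)[nH]c2ccccc2c1=O`, is compound 1 with a single change: hydrogen in place of carboxy on an aromatic carbon. Within the data shown here, no measured pair shows this change on its own, so its size can only be judged indirectly. The closest guide is compound 3, which carries no carboxy group and gives 49 nM, although it is not otherwise identical to compound 4. A lower number, meaning a stronger inhibitor, is therefore expected, with an estimated step of a 10-fold lower number from compound 1 to compound 4 (1.00 log units; beyond the scatter), which would lie beyond the scatter of this assay. The expected value for compound 4 is 40 nM, with an estimated range from 12 nM to 140 nM.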

Compound 4, half-maximal inhibitory concentration: 8.9 nM
Compound 4: the middle estimate sits 4.5-fold (0.65 log units) above what was measured; measured number below the stated range.
By their numbers in this assay, from the lowest: compounds 2 and 4 (each within the scatter of the next); then compound 3; then compound 1.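

Among these compounds, compound 1 and compound 4 form the first pair that isolates this change, and in this assay hydrogen in place of carboxy gives a 45-fold lower number from compound 1 to compound 4 (1.65 log units; beyond the scatter), a large step. The two compounds differ only at this aromatic carbon, the one meta to a fused ring and para to a fused ring, so the whole step belongs to the loss of the carboxy group from this place on the shared core. No measurement here explains why this change has such a large effect on the number, so the pair shows its size but not its cause.

From the compounds shown here alone, it remains open whether the full carboxy group has to go, or whether a methyl ester or a primary amide on the same carbon would give a number closer to that of compound 4 than to that of compound 1. Also unresolved is how a small replacement such as fluorine or a methoxy group would compare with hydrogen here, and whether a carboxy group on another aromatic carbon of the core would give a step of similar size.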